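The source may hold more compounds than are shown below. What is called first, only, known or untested is meant among the compounds shown, and "the series" means these compounds.

In a functional assay on NCI-H460 cells (Homo sapiens) for cytotoxicity, read by MTT assay, with a stated time of 72 h (on this read-out higher numbers stand for weaker inhibition and lower numbers for stronger inhibition), compound 1 `CN(C)CCn1cnnc1-c1cc(Oc2ccc(NC(=O)N/N=C/c3c[nH]c4ccccc34)cc2F)ccn1` gives 1630 nM, the lowest of the three numbers, though both companions lie within the scatter of it. Compound 2 `COc1ccc(/C=N/NC(=O)Nc2ccc(Oc3ccnc(-c4nncn4CCN(C)C)c3)c(F)c2)c(OC)c1OC` gives 1790 nM and compound 3 `CN(C)CCn1cnnc1-c1cc(Oc2ccc(NC(=O)N/N=C/c3ccc(F)cc3F)cc2F)ccn1` gives 1930 nM. Compound 4 `CN(C)CCn1cnnc1-c1cc(Oc2ccc(NC(=O)N/N=C/c3ccc(Cl)cc3)cc2F)ccn1` is still unmeasured in this assay; it differs from compound 1 by 4-chlorophenyl in place of 1H-indol-3-yl on a carbon with a double bond to nitrogen. Two measured steps replace the group at this same position: a 1.1-fold higher number from compound 1 to compound 2 (0.04 log units; within the scatter) and a 1.2-fold higher number from compound 1 to compound 3 (0.07 log units; within the scatter), both within the scatter, as is a 1.1-fold higher number from compound 2 to compound 3 (0.03 log units; within the scatter). Three different aryl groups on the carbon with a double bond to nitrogen thus give much the same number, so a fourth is expected to behave alike. In this assay compound 4 is expected to show a 1.2-fold higher number from compound 1 to compound 4 (0.07 log units; within the scatter), no step beyond the scatter. The estimated value for compound 4 is 1900 nM, within 1000 nM to 3600 nM.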

Compound 4, half-maximal inhibitory concentration: 320 nM
Beside the measured number, compound 4's estimate is 5.9-fold (0.77 log units) above it, outside the stated range (below it).
By their numbers in this assay, from the lowest: compound 4; then compounds 1, 2 and 3 (each within the scatter of the next).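

In this assay the position on the carbon with a double bond to nitrogen proves sensitive to the aryl group after all: 4-chlorophenyl gives a 5.1-fold lower number from compound 1 to compound 4 (0.71 log units; beyond the scatter) and a 5.6-fold lower number from compound 2 to compound 4 (0.75 log units; beyond the scatter) and a 6.0-fold lower number from compound 3 to compound 4 (0.78 log units; beyond the scatter). Halogen on the phenyl ring does not by itself bring this step, since compound 3 with its 2,4-difluorophenyl stays level with compounds 1 and 2. Nothing available accounts for the step. The compounds shown leave open whether 4-bromophenyl or 4-methylphenyl would match 4-chlorophenyl, and what 3-chlorophenyl would give.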